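The source may report more compounds than this note shows. Statements on the series, on what has been measured and on what is new or still open speak of the compounds shown alone.

Measured compounds:
compound 1 `COC(=O)c1c(-c2ccc([N+](=O)[O-])cc2)oc2ccccc2c1=O`, > 25 ug/mL
compound 2 `COC(=O)c1c(-c2ccc(N)cc2)oc2ccccc2c1=O`, > 25 ug/mL
compound 3 `O=c1cc(-c2ccc([N+](=O)[O-])cc2)oc2ccc(O)cc12`, > 25 ug/mL

In a functional assay on Malme-3M cells (Homo sapiens) for cytotoxicity, read by MTT assay, with a stated time of 6 days (a lower number here means that less compound is needed, a higher number that more compound is needed for the effect), compound 1 gives > 25 ug/mL, which is a limit of the assay. Compound 2 likewise gives > 25 ug/mL, a limit. Compound 3 gives > 25 ug/mL, again a limit. The change from compound 1 to compound 2 is amino in place of nitro on an aromatic carbon; its step, a step that the two limits leave unreadable from compound 1 to compound 2, cannot be read because the limit of > 25 ug/mL in this assay, at which 3 of the 3 values shown sit, holds both ends. The difference between the core of compound 1 and the core of compound 3 is not broken down here.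

Compound 4 `Nc1ccc(-c2cc(=O)c3cc(O)ccc3o2)cc1` is not yet measured. It differs from compound 3 by amino in place of nitro on an aromatic carbon, the same change as from compound 1 to compound 2. For compound 4 in this assay the step that the limit leaves unreadable from compound 3 to compound 4 is expected to be small, resting on (the limit of > 25 ug/mL in this assay, at which 3 of the 3 values shown sit). Compound 4 is estimated at 30 ug/mL.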

Compound 4, concentration for half-maximal effect: > 25 ug/mL
Compound 4: a limit, no number; the forecaster's own chance of this, stated with the estimate: 80%; the middle value is on the limit's open side.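

The step between compound 3 and compound 4 cannot be read in this assay because both values are limits: the limit of > 25 ug/mL in this assay, at which 4 of the 4 values shown sit.

The compounds shown leave open what number any of them would give, and whether amino in place of nitro alters cytotoxicity at all.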